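Acetyl to 4-chlorophenyl ketone on a shared benzoxaborole core

This account rests on a few compounds, and the source may have more. Where it says the series, first, only, none or still open, it means among the compounds named here.

Measured compounds in an ADME assay on L929 cells (Mus musculus) for cytotoxicity, read by resazurin assay, with a stated time of 72 h; on this read-out higher numbers stand for weaker inhibition and lower numbers for stronger inhibition:
compound 1, `OB1OCc2ccc(-n3cccc3)cc21`, gives > 10 ug/mL, which is a limit of the assay.
compound 2, `O=C(NC1CCCCC1)c1cccn1-c1ccc2c(c1)B(O)OC2`, gives > 10 ug/mL, which is a limit of the assay.
compound 3, `CC(=O)c1ccn(-c2ccc3c(c2)B(O)OC3)c1`, gives > 10 ug/mL, which is a limit of the assay.

Compound 3 therefore stands only at a limit in this assay, not at a number, and the same holds for the two other measured compounds, as shown by the limit of > 10 ug/mL in this assay, at which 3 of the 3 values shown sit. For the measured compounds named here, the one single-change step among them, a step that the two limits leave unreadable from compound 1 to compound 3, runs from one limit to another and cannot be read in size or direction.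

Compound 4, `O=C(c1ccc(Cl)cc1)c1ccn(-c2ccc3c(c2)B(O)OC3)c1`, differs from compound 3 by 4-chlorophenyl in place of methyl on a carbonyl carbon. Going by the values given here, no measured step in this set bears on such a change, since the only step available is unreadable. What can be said is that every measured compound, including compound 3, sits at the limit of this assay, so a value near that limit is the expectation for compound 4 as well; the size of a step that the limit leaves unreadable from compound 3 to compound 4 is expected to stay within the scatter. Compound 4 is estimated at 15 ug/mL, with a range from 4 ug/mL to 60 ug/mL, and a limit rather than a number is the more likely report.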

Compound 4, half-maximal inhibitory concentration: > 10 ug/mL
Compound 4 ended at the assay's limit; the forecaster's own chance of this, stated with the estimate: 70%; the middle value does not contradict the limit.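

Compound 3 and compound 4 both stand at a limit in this assay, and the step between them cannot be read in size or direction. All the compounds shown share that position: the limit of > 10 ug/mL in this assay, at which 4 of the 4 values shown sit. They leave open what number any of them would give in this assay, and whether 4-chlorophenyl in place of methyl changes it.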